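A furan-to-aminopyridine swap on the shared core

The source may report more compounds than this note shows. Statements on the series, on what has been measured and on what is new or still open speak of the compounds shown alone.

Three compounds built on the same carboxymethyl-bearing core have been run through an in vitro assay on HEK385-7 cells for displacement of a labelled ligand from prostaglandin D2 receptor 2 (Homo sapiens); on this read-out higher numbers stand for weaker inhibition and lower numbers for stronger inhibition. Compound 1 `O=C(O)Cc1sc(CS(=O)(=O)c2ccc(Cl)cc2)nc1-c1ccc(Cl)cc1` gives 1500 nM, compound 2 `COc1ccc(C(c2ccccc2)c2nc(-c3ccc(Cl)cc3)c(CC(=O)O)s2)cc1` gives 8.4 nM, and compound 3 `O=C(O)Cc1sc(C(c2ccc(F)cc2)c2ccc(F)cc2)nc1-c1ccco1` gives 18 nM. On these numbers compound 3 holds the second highest value of the three: its nearest neighbour is compound 2, which sits at a lower number beyond the scatter, while compound 1 lies far above it, also beyond the scatter.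

Compound 4 `Cc1cc(-c2nc(C(c3ccc(F)cc3)c3ccc(F)cc3)sc2CC(=O)O)cnc1N` has not yet been measured. It differs from compound 3 in one place: 6-amino-5-methylpyridin-3-yl in place of furan-2-yl on an aromatic carbon. The furan-2-yl group leaves the aromatic carbon of the five-membered ring and 6-amino-5-methylpyridin-3-yl enters in its stead.

Among the compounds with values here, no measured pair isolates this change, so any expectation rests on the broader picture. Compound 2, whose structure also shows a six-membered aromatic ring on the shared core, gives 8.4 nM in this assay, a lower number than compound 3. On that basis the step of a 1.5-fold lower number from compound 3 to compound 4 (0.18 log units; within the scatter) is expected to be small, at most a modest move toward stronger inhibition and possibly none beyond the scatter. Compound 4 is therefore estimated at 12 nM, with a range from 4 nM to 40 nM.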

Compound 4, half-maximal inhibitory concentration: 880 nM
Beside the measured number, compound 4's estimate is 73-fold (1.87 log units) below it, outside the stated range (above it).
By their numbers in this assay, from the lowest: compound 2; then compound 3; then compounds 4 and 1 (each within the scatter of the next).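

In this assay, putting 6-amino-5-methylpyridin-3-yl in place of furan-2-yl on the aromatic carbon next to the ring nitrogen gives a 49-fold higher number from compound 3 to compound 4 (1.69 log units; beyond the scatter) as a large step. Within the data shown here, with everything else in compound 3 held fixed, this is the first direct reading at this position, and it shows that the group on this carbon can by itself move the number a long way. No measurement at hand says what lies behind the step.

The compounds shown leave open which part of the entering group goes with the step: the amino group, the methyl group or the six-membered aromatic ring itself. Going by these compounds, whether a plain pyridin-3-yl or a phenyl on this carbon, with the rest of compound 3 unchanged, would stay near compound 3 or near compound 4 also remains open.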